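The compounds below may be only part of what the source reports. "The series", "measured", "known", "first", "only" and "open" are said of these compounds alone.

Compound 1 `Cc1cc(C)c(Oc2cc(Nc3ccc(C#N)cc3)ncc2C(=O)NCc2cn(Cc3ccccc3Cl)nn2)c(C)c1` and compound 2 `Cc1cc(C)c(Oc2cc(Nc3ccc(C#N)cc3)ncc2C(=O)NCc2cn(Cc3ccc(F)cc3)nn2)c(C)c1` share a common core and differ only in the 2-chlorophenyl against 4-fluorophenyl group on the saturated chain carbon bound to the aromatic nitrogen. In an ADME assay on MT4 cells (Homo sapiens) for cytotoxicity, read by MTT assay, with a stated time of 5 days (a higher number here means that more compound is tolerated, a lower number that less compound is tolerated), compound 1 gives only a limit, >= 188000 nM. In this assay compound 2 likewise gives only a limit, >= 153000 nM. The one measured step, a step that the two limits leave unreadable from compound 1 to compound 2, therefore carries no readable size, and compound 2 stands at one of two limits shown, the limit of >= 153000 nM in this assay, at which 1 of the 2 values shown sits, beside (the limit of >= 188000 nM in this assay, at which 1 of the 2 values shown sits).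

Compound 3 `Cc1cc(C)c(Oc2cc(Nc3ccc(C#N)cc3)ncc2C(=O)NCc2cn(Cc3ccc([N+](=O)[O-])cc3)nn2)c(C)c1` carries the change (nitro in place of fluoro on an aromatic carbon). With both neighbours sitting at limits, the measured step offers no direction for this change in this assay. Compound 3 is expected to come out near 150000 nM, with a range of 60000 nM to 300000 nM, most probably again as a limit. The estimated step is an at least 1.0-fold lower number from compound 2 to compound 3 (0.00 log units; that floor lies within the scatter), not beyond the scatter.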

Compound 3, half-maximal cytotoxic concentration: >= 139000 nM
Compound 3 was reported as a limit; the forecaster's own chance of this, stated with the estimate: 75%; the middle value lies beyond the limit too.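

In this assay compound 3 gives >= 139000 nM, which is a limit, and the steps to compound 3 from compound 1 and compound 2 cannot be read. The compounds shown leave open where their cytotoxic concentrations lie and whether the 2-chlorophenyl, 4-fluorophenyl and 4-nitrophenyl groups differ at all.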